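A few compounds are considered here, and "the series" means these few. Any claim that something is new, unique, unknown or untested is made for them only; others in the source may bear on it.

Within the data shown here, in a functional assay on HCT-116 cells (Homo sapiens) for inhibition, read by MTT assay, with a stated time of 48 h (a higher number here means a weaker inhibitor, a lower number a stronger inhibitor), two compounds that share one core have numbers so far. Compound 1 `C#CC(=O)N(Cc1ccc(OC)c(O)c1)c1cc(OC)c(OC)c(OC)c1` gives 310 nM. Compound 2 `CC/C=C/C(=O)N(Cc1ccc(OC)c(O)c1)c1cc(OC)c(OC)c(OC)c1` gives 63 nM, the lower of the two numbers, which makes it the stronger inhibitor of this pair. Compound 3 `COc1ccc(CN(C(=O)CCCCCl)c2cc(OC)c(OC)c(OC)c2)cc1O` keeps the shared core and has not yet been measured. Among the measured compounds shown here, its one change from compound 2 is 4-chlorobutyl in place of but-1-en-1-yl on a carbonyl carbon. For the measured compounds named here, only one measured step touches this same place: a 4.9-fold lower number from compound 1 to compound 2 (0.69 log units; beyond the scatter), a modest step beyond the scatter. That step shows the number can move with this group, but it involves a different pair of groups, so it is only a loose guide. A step of similar or smaller size towards a higher number is therefore expected. The expected change is a 1.9-fold higher number from compound 2 to compound 3 (0.28 log units; within the scatter). In this assay, compound 3 is estimated at 120 nM, with a range from 30 nM to 450 nM.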

Compound 3, half-maximal inhibitory concentration: 220 nM
Compound 3: middle estimate off by 1.8-fold (0.26 log units), on the low side; low and high end bracket the measured number.
By their numbers in this assay, from the lowest: compound 2; then compounds 3 and 1 (each within the scatter of the next).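

In this assay, a 3.5-fold higher number from compound 2 to compound 3 (0.54 log units; beyond the scatter) marks the change from but-1-en-1-yl to 4-chlorobutyl on this carbonyl carbon, so compound 2 now stands apart from two different groups at this position, not only from ethynyl. The second comparison, a 1.4-fold lower number from compound 1 to compound 3 (0.15 log units; within the scatter) for 4-chlorobutyl in place of ethynyl, lies within the scatter, so this assay does not separate these two groups even though their structures differ considerably. Nothing available explains why this position responds in this way.

The change from compound 2 to compound 3 removes the double bond and adds the chlorine together, so the compounds shown leave open which of these goes with the higher number. From the compounds shown here alone, how a plain butyl chain or an amine would compare at this position also remains open.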